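Adding a Methyl Group on Two Different Cores

The compounds below may be only part of what the source reports. "The series", "measured", "known", "first", "only" and "open" are said of these compounds alone.

Two cores appear in this small set. Compound 1 `Cc1cc(NNC(=O)Nc2cc(Cl)nc(Cl)c2)ncc1-c1cnn(C)c1` and compound 2 `Cc1cc(NNC(=O)Nc2cc(Cl)nc(Cl)c2)ncc1-c1cn(C)nc1C` share one of them and differ in a single spot: methyl in place of hydrogen on an aromatic carbon. In a functional assay on CHO cells for antagonist activity at sphingosine 1-phosphate receptor 2 (Homo sapiens), read by scintillation counting and GTPgammaS binding, with a stated time of 4 h, in the presence of a further agent that is not named here (on this read-out lower numbers stand for stronger inhibition and higher numbers for weaker inhibition), compound 1 gives 3.4 nM, while compound 2 gives 0.8 nM, which amounts to a 4.3-fold lower number from compound 1 to compound 2 (0.63 log units; beyond the scatter).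

Compound 3 `Cc1cc(CNC(=O)Nc2cc(OCCO)nc(C(F)(F)F)c2)nnc1-c1cn(C)nc1C(F)(F)F` is built on the other core; the difference between the two cores is not broken down here. In this assay compound 3 gives 704 nM, a far higher number than either compound 1 or compound 2.

Compound 4 `Cc1cc(CNC(=O)Nc2cc(C(F)(F)F)nc(OCCO)c2C)nnc1-c1cn(C)nc1C(F)(F)F` has not yet been measured. It differs from compound 3 by methyl in place of hydrogen on an aromatic carbon. For the measured compounds named here, this is the same kind of change as the one from compound 1 to compound 2, not the same change: in compound 2 the methyl enters a five-membered aromatic ring with 2 nitrogen, next to the ring nitrogen and next to the ring atom that bears a large group, whereas in compound 4 it enters a six-membered aromatic ring with 1 nitrogen, ortho to a 2-hydroxyethoxy group, two atoms from the ring nitrogen and para to a trifluoromethyl group.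

Because the earlier step of a 4.3-fold lower number from compound 1 to compound 2 (0.63 log units; beyond the scatter) was seen, a lower number is expected for compound 4, but the different ring, surroundings and core make a smaller step the safer expectation. For compound 4 the expected step is a 2.0-fold lower number from compound 3 to compound 4 (0.30 log units; within the scatter). Compound 4 is thus estimated at 350 nM, most likely between 120 nM and 1000 nM.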

Compound 4, half-maximal inhibitory concentration: 169 nM
Estimate against measurement, compound 4: 2.1-fold (0.32 log units) above; the measured number falls inside the stated range.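

In this assay the methyl again goes with a lower number, a 4.2-fold lower number from compound 3 to compound 4 (0.62 log units; beyond the scatter), so the step seen on the core of compound 1 also appears on the core of compound 3, even though the numbers on that second core are much higher. Set side by side, the two steps match in size: the same change on two cores in this assay, a 4.3-fold lower number (0.63 log units; beyond the scatter) from compound 1 to compound 2 and a 4.2-fold lower number (0.62 log units; beyond the scatter) from compound 3 to compound 4, 1.0-fold (0.01 log units) apart, within the scatter of two such steps. For the compounds shown here, this does not show that a methyl has a fixed worth: there are only two pairs, the methyl enters a five-membered ring in compound 2 but a six-membered ring in compound 4, and steps of equal size need not have the same cause.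

The compounds shown leave open whether a methyl on the six-membered ring of the core of compound 1, which carries two chlorines rather than trifluoromethyl and 2-hydroxyethoxy groups, would give a step of similar size. They also leave open how a larger ethyl group, or a chlorine atom, on the same carbon as the new methyl of compound 4 would change the number.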